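A few compounds are considered here, and "the series" means these few. Any claim that something is new, unique, unknown or untested is made for them only; others in the source may bear on it.

Compound 1 `O=S(=O)(c1cccc(F)c1)c1cn(C2CCNC2)c2ncccc12`: 44%
Compound 2 `O=S(=O)(c1cccc(Br)c1)c1cn(C2CCNC2)c2ncccc12`: 49%
Compound 3 `O=S(=O)(c1cccc(C(F)(F)F)c1)c1cn(C2CCNC2)c2ncccc12`: 41%

These three values come from a functional assay on HeLa cells for agonist activity at 5-hydroxytryptamine receptor 6 (Homo sapiens), read by cAMP accumulation and immunoassay; a higher number here means a larger maximal response, a lower number a smaller maximal response. Compound 3 carries the lowest of the three numbers, yet the measured steps that end at it are a number 3 percentage points lower from compound 1 to compound 3 (within the scatter) and a number 8 percentage points lower from compound 2 to compound 3 (within the scatter), so none of the three stands apart. All measured steps, a number 5 percentage points higher from compound 1 to compound 2 (within the scatter) included, concern the group on the aromatic carbon and lie within the scatter. Compound 4 `CN1CCCC(n2cc(S(=O)(=O)c3cccc(C(F)(F)F)c3)c3cccnc32)C1` differs from compound 3 elsewhere: 1-methylpiperidin-3-yl in place of pyrrolidin-3-yl on an aromatic nitrogen. Among the measured compounds shown here, no measured step touches this part of the molecule, so the data give no direction for it. Compound 4 is therefore expected to stay close to where compound 3 stands. The expected step is no change at the digits printed from compound 3 to compound 4 (within the scatter). For compound 4 the estimate is 41%, from 22% to 62%. For the measured compounds named here, no comparable step has been measured, and the range is kept wide.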

Compound 4, largest response reached (Emax), in percent of the reference or control that the assay uses: 66%
The estimate for compound 4 lay 25 percentage points below the measured number; the whole stated range lies below it.
By their numbers in this assay, from the lowest: compounds 3, 1 and 2 (each within the scatter of the next); then compound 4.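

In this assay the group on the aromatic nitrogen turned out to matter, with a number 25 percentage points higher from compound 3 to compound 4 (beyond the scatter), whereas every step on the aromatic carbon stayed within the scatter. This position therefore responds to a change where the aromatic carbon had shown no clear response. Nothing available explains this step. The change swaps a five-membered ring for a six-membered one and adds a methyl together, and the compounds shown do not separate the two. As far as these compounds go, whether piperidin-3-yl or 1-methylpyrrolidin-3-yl alone would give the same step remains open.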